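This account rests on a few compounds, and the source may have more. Where it says the series, first, only, none or still open, it means among the compounds named here.

Working notes on the series, step from compound 3 to compound 4. The three measured compounds share one core and differ only in the chain on the aromatic nitrogen. In an assay on isolated protein (Oryctolagus cuniculus) with Thromboxane-A synthase (Homo sapiens) as the target, tested at 1 uM (on this read-out lower numbers stand for less inhibition and higher numbers for more inhibition at the one concentration tested (going by the name of the read-out)), compound 1 `CCCn1nc(-c2cccnc2)c2ccccc2c1=O` gives 86%, compound 2 `CCCCn1nc(-c2cccnc2)c2ccccc2c1=O` gives 91%, and compound 3 `O=c1c2ccccc2c(-c2cccnc2)nn1Cc1ccccc1` gives 97%. Compound 3 stands highest of the three numbers; its nearest neighbour is compound 2, with a number 6 percentage points higher from compound 2 to compound 3 (within the scatter), and the furthest is compound 1, with a number 11 percentage points higher from compound 1 to compound 3 (beyond the scatter). The remaining comparison, a number 5 percentage points higher from compound 1 to compound 2 (within the scatter), is of the same order.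

Compound 4 `COC(=O)c1ccc(Cn2nc(-c3cccnc3)c3ccccc3c2=O)cc1` differs from compound 3 in one place: methoxycarbonyl in place of hydrogen on an aromatic carbon. The entering group sits on an aromatic carbon of the six-membered aromatic ring of carbon only, para to a large group.

Within the data shown here, none of the measured steps touches that ring; all three concern the chain on the aromatic nitrogen, and their sizes were all within or only modestly beyond the scatter. Among the measured compounds shown here, no measured step therefore bears directly on the change, and the only guidance is that compound 3 already gives 97%, leaving little room upward in this assay. The expected step is a number 4 percentage points lower from compound 3 to compound 4 (within the scatter), none beyond the scatter. The estimate for compound 4 in this assay is 93%, in the range 80% to 99%.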

Compound 4, a percentage reported as inhibition, at one concentration (the size of the read-out at that concentration, not a potency): 95%
For compound 4 the middle estimate is 2 percentage points below the measured one, and the stated range covers the measured number.
By their numbers in this assay, from the lowest: compounds 1, 2, 4 and 3 (each within the scatter of the next, the first and the last beyond it).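

In this assay, among these compounds, the first change on the six-membered aromatic ring of carbon only gives a number 2 percentage points lower from compound 3 to compound 4 (within the scatter) and so shows that this ring, unlike the chain on the aromatic nitrogen in the earlier steps, can carry a substituent para to a large group with no change beyond the scatter. Methoxycarbonyl in place of hydrogen on an aromatic carbon therefore leaves the number in the range already reached by the benzyl-bearing compound 3, and compound 4 at 95% stays close to the top of the percentage scale at the one concentration tested. Nothing available here accounts for this result.

The compounds shown leave open whether a carboxylic acid, an amine or a longer ester in the same place would keep the number this high, and how methoxycarbonyl would fare elsewhere on that ring. They also leave open whether compound 3 and compound 4 differ in potency, since a read-out at a single concentration this near the top of the scale cannot tell them apart.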